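The source may report more compounds than this note shows. Statements on the series, on what has been measured and on what is new or still open speak of the compounds shown alone.

Working notes on the naphthyloxyacetyl hydrazone series.

Compound 1 `O=C(COc1cccc2ccccc12)N/N=C/c1ccccc1Br` and compound 2 `O=C(COc1cccc2ccccc12)N/N=C/c1ccccc1[N+](=O)[O-]` share the same core and differ only at one aromatic carbon. For the measured compounds named here, in an ADME assay on HEL cells (Homo sapiens) for cytotoxicity (a lower number here means that less compound is tolerated, a higher number that more compound is tolerated), compound 1 gives 100 ug/mL and compound 2 gives 100 ug/mL, so the one measured step, no change at the digits printed from compound 1 to compound 2 (within the scatter), stays within the scatter. Going by the values given here, compound 1 therefore stands level with compound 2 at the digits printed; there is no spread so far to rank against.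

Compound 3 `COc1ccc(/C=N/NC(=O)COc2cccc3ccccc23)cc1` is the next member. Its difference from compound 1 is 4-methoxyphenyl in place of 2-bromophenyl on a carbon with a double bond to nitrogen. Among the compounds with values here, the only step measured so far concerns a nitro in place of bromo on an aromatic carbon and produced no change, which is a smaller and differently placed change than the swap of the whole aryl group on the carbon with a double bond to nitrogen in compound 3. Within the data shown here, nothing measured points to either direction, and the sole precedent is flat, so the expected step of no change at the digits printed from compound 1 to compound 3 (within the scatter) is none beyond the scatter. Compound 3 is estimated at 100 ug/mL in this assay, with a range from 50 ug/mL to 150 ug/mL.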

Compound 3, half-maximal cytotoxic concentration: 100 ug/mL
Compound 3: the middle estimate sits on the measured number at the digits printed; measured number inside the range.
By their numbers in this assay, from the lowest: compounds 1, 2 and 3 (each within the scatter of the next).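

In this assay, for the compounds shown here, the swap of 4-methoxyphenyl for 2-bromophenyl on a carbon with a double bond to nitrogen gives no change at the digits printed from compound 1 to compound 3 (within the scatter), so the flat reading now extends beyond the single aromatic-carbon exchange between compound 1 and compound 2 to a replacement of the whole aryl group. The entering group differs from the leaving one in its heavy-atom make-up, with oxygen and an extra carbon in place of bromine, and it carries a hydrogen-bond acceptor where the 2-bromophenyl carries none, yet compound 3 reads 100 ug/mL, so across these three compounds neither difference separates the values in this assay. No supporting data bear on why the values coincide.

Going by these compounds, all three compounds keep an aryl group at this place on the shared core, so what an amine or a carboxylic acid on that ring, or a saturated alkyl chain in place of the ring, would do to the tolerated concentration remains open. The shown set also leaves open any change to the shared core itself, since every step so far falls on the aryl end of the hydrazone.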